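Thiophen-2-yl in place of furan-2-yl: working notes

A few compounds are considered here, and "the series" means these few. Any claim that something is new, unique, unknown or untested is made for them only; others in the source may bear on it.

In a functional assay on HeLa S3 cells (Homo sapiens) for antiproliferative activity, read by XTT assay, with a stated time of 72 h (on this read-out higher numbers stand for weaker inhibition and lower numbers for stronger inhibition), compound 1 `CSc1ncnc2c1c(-c1cccs1)cn2[C@@H]1O[C@H](CO)[C@@H](O)[C@H]1O` gives 1960 nM. Compound 2 `CNc1ncnc2c1c(-c1ccco1)cn2[C@@H]1O[C@H](CO)[C@@H](O)[C@H]1O` gives 5000 nM, the higher of the two numbers and thus the weaker inhibition, with a gap beyond the scatter. Compound 3 `CNc1ncnc2c1c(-c1cccs1)cn2[C@@H]1O[C@H](CO)[C@@H](O)[C@H]1O` has thiophen-2-yl in place of furan-2-yl on an aromatic carbon. Going by the values given here, no measured pair isolates this change. Compound 1, at 1960 nM, also carries thiophen-2-yl but differs elsewhere, so a moderate move toward stronger inhibition is expected in this assay. The estimated step is a 3.3-fold lower number from compound 2 to compound 3 (0.52 log units; beyond the scatter). Compound 3 is expected at 1500 nM, with an estimated range from 350 nM to 6000 nM.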

Compound 3, half-maximal inhibitory concentration: > 20000 nM
Compound 3 was reported as a limit (the forecaster's own chance of this, stated with the estimate: 5%); middle value at least 13-fold (1.12 log units) from the limit.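

With methylamino held, thiophen-2-yl in place of furan-2-yl gives an at least 4.0-fold higher number from compound 2 to compound 3 (0.60 log units; beyond the scatter) in this assay, so this change on the aromatic carbon weakens inhibition rather than strengthening it. With thiophen-2-yl held, methylamino in place of methylsulfanyl gives an at least 10-fold higher number from compound 1 to compound 3 (1.00 log units; beyond the scatter), so thiophen-2-yl alone does not secure the activity of compound 1. The reading for compound 3 is a limit of the assay, not a number: the limit of > 20000 nM in this assay, at which 1 of the 3 values shown sits.

Still open, as far as these compounds go, is how furan-2-yl reads alongside methylsulfanyl. Also open, from the compounds shown here alone, is how a plain amino group in place of methylamino reads with either ring.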